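From cyano to amino: one change, one guide

A few compounds are considered here, and "the series" means these few. Any claim that something is new, unique, unknown or untested is made for them only; others in the source may bear on it.

In a functional assay on P388 cells (Mus musculus) for antiproliferative activity (on this read-out higher numbers stand for weaker inhibition and lower numbers for stronger inhibition), compound 1 (`COc1ccc(S(=O)(=O)Nc2cccc3cc[nH]c23)cc1`) gives 1.1 ug/mL and compound 2 (`N#Cc1ccc(S(=O)(=O)Nc2cccc3cc[nH]c23)cc1`) gives 4.2 ug/mL, the higher of the two numbers and so the weaker inhibition. Compound 3 (`Nc1ccc(S(=O)(=O)Nc2cccc3cc[nH]c23)cc1`) has not yet been measured and differs from compound 2 in one place (amino in place of cyano on an aromatic carbon): amino in place of cyano on an aromatic carbon, para to a large group. For the measured compounds named here, the only measured step that bears on this (a 3.8-fold higher number from compound 1 to compound 2 (0.58 log units; beyond the scatter)) brought cyano in place of methoxy and was modest, though beyond the scatter. Going by the values given here, with cyano now leaving compound 2, a step of similar or smaller size toward a lower number is expected in this assay, although no amino compound has been measured. The estimated step (a 2.6-fold lower number from compound 2 to compound 3 (0.42 log units; beyond the scatter)) follows that reasoning. For compound 3 the estimated value is 1.6 ug/mL with an expected range from 0.5 ug/mL to 4.5 ug/mL as its limits.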

Compound 3, half-maximal inhibitory concentration: 14 ug/mL
Estimate against measurement, compound 3: 8.8-fold (0.94 log units) below; measured number above the stated range.
By their numbers in this assay, from the lowest: compound 1; then compound 2; then compound 3.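

In this assay the swap to amino gave a 3.3-fold higher number from compound 2 to compound 3 (0.52 log units; beyond the scatter) and so carried the number the same way as the earlier swap from methoxy to cyano, not back toward compound 1. Measured directly against methoxy, amino gives a 13-fold higher number from compound 1 to compound 3 (1.10 log units; beyond the scatter) as the largest step among these three compounds, so this aromatic carbon, para to a large group, separates the three groups clearly, with methoxy lowest, cyano in the middle and amino highest. Nothing available here explains why the groups fall in this order.

The compounds shown leave open where a hydroxyl, a dimethylamino group or a carboxylic acid on this same carbon would fall in that order. They also leave open whether an ethoxy group, a longer chain on the same oxygen as methoxy, would keep or lower the number.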